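Working notes on cell tolerance in this series

The source may hold more compounds than are shown below. What is called first, only, known or untested is meant among the compounds shown, and "the series" means these compounds.

Compound 1 `CC(C)c1ccc2[nH]c(=O)c(CN(Cc3ccc(F)cc3)Cc3ccc(C(C)(C)C)cc3)cc2c1` gives 7900 nM in a toxicity assay on MDCK cells (Canis lupus familiaris) for cytotoxicity, read by crystal violet staining, with a stated time of 48 h; a lower number here means that less compound is tolerated, a higher number that more compound is tolerated. Compound 2 `CCCCOc1ccc(CN(Cc2ccc(C(C)(C)C)cc2)Cc2cc3cc(C)ccc3[nH]c2=O)cc1` reaches only a limit of the assay, > 5000 nM in this assay, so no number exists for it. Compound 3 `CCc1ccc2[nH]c(=O)c(CN(Cc3ccc(C(C)(C)C)cc3)[C@@H](C)c3ccc(F)cc3)cc2c1` likewise ends at a limit, > 5000 nM in this assay. Compound 2 thus stands at the limit of > 5000 nM in this assay, at which 2 of the 3 values shown sit, and it cannot be ranked against the number of compound 1.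

Compound 4 `Cc1ccc2[nH]c(=O)c(CN(Cc3ccc(C(C)(C)C)cc3)C(C)c3ccc(OC(F)F)cc3)cc2c1` differs from compound 2 by 1-(4-(difluoromethoxy)phenyl)ethyl in place of 4-butoxybenzyl on an amine nitrogen. Among the measured compounds shown here, no pair of measured compounds here differs in a single place, so no measured step gives the size of such a change. Since compound 3 also stops at a limit, the step that the limit leaves unreadable from compound 2 to compound 4 is expected to stay within the scatter, with a limit again likely. Compound 4 is estimated at 8000 nM, ranging from 3000 nM to 25000 nM.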

Compound 4, half-maximal cytotoxic concentration: > 5000 nM
Compound 4 gave a limit, no number (the forecaster's own chance of this, stated with the estimate: 60%); the middle value does not contradict the limit.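

Among the compounds shown here, compound 2 and compound 4 both end at a limit of the assay, and no step between them can be read. On these data alone, whether 1-(4-(difluoromethoxy)phenyl)ethyl in place of 4-butoxybenzyl on an amine nitrogen changes cell tolerance at all stays open.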